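Ether aryl swap: expectation for compound 4

This account rests on a few compounds, and the source may have more. Where it says the series, first, only, none or still open, it means among the compounds named here.

Compound 3 `CC(CCNC(=O)c1c(Cl)cncc1Cl)N1CCC(C(Oc2cc(Cl)ccn2)c2ccc(C(F)(F)F)cc2)CC1` holds the second highest of the three numbers in an ADME assay on PBMC cells (Homo sapiens) for cytotoxicity (on this read-out lower numbers stand for higher toxicity in this test and higher numbers for lower toxicity in this test), where compound 3 gives 4260 nM. Its nearest neighbour is compound 2 `CC(CCNC(=O)c1c(Cl)cncc1Cl)N1CCC(C(Oc2ccc(C(F)(F)F)cc2)c2ccc(C(F)(F)F)cc2)CC1`, which in this assay gives 3100 nM; the two lie within the scatter of each other. Compound 1 `COC(=O)c1cccc(OC(c2ccc(C(F)(F)F)cc2)C2CCN(C(C)CCNC(=O)c3c(Cl)cncc3Cl)CC2)n1` stands furthest away and in this assay gives 14600 nM.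

Compound 4 `CC(CCNC(=O)c1c(Cl)cncc1Cl)N1CCC(C(Oc2ccccc2Cl)c2ccc(C(F)(F)F)cc2)CC1` differs from compound 3 in a single place: 2-chlorophenyl in place of 4-chloropyridin-2-yl on an oxygen on a saturated carbon.

For the measured compounds named here, three measured steps concern the same oxygen on a saturated carbon. a 4.7-fold lower number from compound 1 to compound 2 (0.67 log units; beyond the scatter) and a 3.4-fold lower number from compound 1 to compound 3 (0.53 log units; beyond the scatter) both move away from the 6-(methoxycarbonyl)pyridin-2-yl group and both fall beyond the scatter. a 1.4-fold higher number from compound 2 to compound 3 (0.14 log units; within the scatter), the swap between the 4-(trifluoromethyl)phenyl and 4-chloropyridin-2-yl groups, stays within the scatter. The change to compound 4 resembles that last step more than the first two, so no step beyond the scatter is expected in this assay; at most a slight drift toward the number of compound 2 is expected, because a 1.4-fold higher number from compound 2 to compound 3 (0.14 log units; within the scatter) stayed within the scatter.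

Compound 4 is therefore estimated at 3500 nM, between 1500 nM and 8500 nM, and the expected step is a 1.2-fold lower number from compound 3 to compound 4 (0.09 log units; within the scatter).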

Compound 4, half-maximal cytotoxic concentration: 4400 nM
The estimate for compound 4 lay 1.3-fold (0.10 log units) below the measured number; measured number inside the range.
By their numbers in this assay, from the lowest: compounds 2, 3 and 4 (each within the scatter of the next); then compound 1.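

Notes on the aryl group on the ether oxygen, read in this assay: the step of a 1.0-fold higher number from compound 3 to compound 4 (0.01 log units; within the scatter) replaces a ring with one hetero atom by a ring of carbon only, and also replaces a 4-chloropyridin-2-yl group carrying a hydrogen-bond acceptor by a 2-chlorophenyl group with none, yet it stays within the scatter. The step of a 1.4-fold higher number from compound 2 to compound 4 (0.15 log units; within the scatter) is also within the scatter, so 2-chlorophenyl, 4-chloropyridin-2-yl and 4-(trifluoromethyl)phenyl cannot be told apart here, while a 3.3-fold lower number from compound 1 to compound 4 (0.52 log units; beyond the scatter) lies beyond it, leaving the 6-(methoxycarbonyl)pyridin-2-yl group of compound 1 as the only one of the four that stands apart, with the highest number. Nothing available explains why this group alone separates from the other three.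

With one ester-bearing compound, the series cannot show whether the higher number of compound 1 follows the methoxycarbonyl group itself or its combination with the pyridine ring. A carboxylic acid or an amine on the same aryl ring would test whether other substituents also separate from the three groups that now sit within the scatter of one another.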